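Adding a Second Fluoro: Expected Effect on Rice

The source may report more compounds than this note shows. Statements on the series, on what has been measured and on what is new or still open speak of the compounds shown alone.

Measured in an ADME assay on the whole organism with Oryza sativa as the target, tested at 1 uM; on this read-out higher numbers stand for a weaker effect at the one concentration tested and lower numbers for a stronger effect:
compound 1, `C[C@H](NC(=O)Nc1cccc(F)c1)c1ccccc1`, 94%
compound 2, `C[C@H](NC(=O)Nc1cccc(Br)c1)c1ccccc1`, 100%
compound 3, `C[C@H](NC(=O)Nc1cccc(I)c1)c1ccccc1`, 95%

Compound 1 has the lowest of the three numbers, yet its steps to compound 3 (a number 1 percentage points higher from compound 1 to compound 3 (within the scatter)) and to compound 2 (a number 6 percentage points higher from compound 1 to compound 2 (within the scatter)) both stay within the scatter, so the three compounds cannot be ordered. The remaining step, a number 5 percentage points lower from compound 2 to compound 3 (within the scatter), is also within the scatter. Compound 4, `C[C@H](NC(=O)Nc1ccc(F)c(F)c1)c1ccccc1`, differs from compound 1 by fluoro in place of hydrogen on an aromatic carbon. Within the data shown here, every measured step swaps one halogen for another and none moved the read-out beyond the scatter; no measured step adds a group, so none bears directly on this change. Compound 4 is therefore expected to stay level with compound 1, a number 1 percentage points higher from compound 1 to compound 4 (within the scatter). Compound 4 is estimated at 95%, between 84% and 100%.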

Compound 4, a percentage reported as activity, at one concentration (the size of the read-out at that concentration, not a potency): 100%
Beside the measured number, compound 4's estimate is 5 percentage points below it; the measured number falls inside the stated range.
By their numbers in this assay, from the lowest: compounds 1, 3, 2 and 4 (each within the scatter of the next).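

Fluoro in place of hydrogen, on an aromatic carbon ortho to a fluoro group and para to a large group, gives a number 6 percentage points higher from compound 1 to compound 4 (within the scatter) in this assay. Where the earlier steps only swapped one halogen for another, this one adds an atom to the core of compound 1, and at this place a single added fluoro does not separate compound 4 from compound 1. Nothing available explains this result.

Still open, from the compounds shown here alone, is whether an amine or a methoxy group at this place would move the read-out beyond the scatter. Also open, going by these compounds, is whether a carboxylic acid there would do so.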